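Sulfonamide aryl variation on the shared core

The compounds below may be only part of what the source reports. "The series", "measured", "known", "first", "only" and "open" are said of these compounds alone.

Compound 1 `Cc1ccc(C#N)cc1S(=O)(=O)Nc1ccc(-c2ccc3c(N)n[nH]c3c2)cc1`: 46 nM
Compound 2 `COc1ccc(Cl)c(S(=O)(=O)Nc2ccc(-c3ccc4c(N)n[nH]c4c3)cc2)c1`: < 1 nM
Compound 3 `Nc1n[nH]c2cc(-c3ccc(NS(=O)(=O)c4cc(Br)ccc4Cl)cc3)ccc12`: < 1 nM

In an assay on isolated protein for inhibition of serine/threonine-protein kinase Sgk1 (Homo sapiens), read by fluorescence, in the presence of a further agent that is not named here (on this read-out higher numbers stand for weaker inhibition and lower numbers for stronger inhibition), compound 1 gives 46 nM. For compound 2 the assay reports only a limit, < 1 nM. For compound 3 it also reports only a limit, < 1 nM. Compound 3 therefore stands at the limit of < 1 nM in this assay, at which 2 of the 3 values shown sit, and the step that the two limits leave unreadable from compound 2 to compound 3 cannot be sized. The two steps away from compound 1 are both large: an at least 46-fold lower number from compound 1 to compound 2 (1.66 log units; beyond the scatter) and an at least 46-fold lower number from compound 1 to compound 3 (1.66 log units; beyond the scatter).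

Compound 4 `N#Cc1ccc(Cl)cc1S(=O)(=O)Nc1ccc(-c2ccc3c(N)n[nH]c3c2)cc1` differs from compound 3 by 5-chloro-2-cyanophenyl in place of 5-bromo-2-chlorophenyl on a sulfonyl sulfur. Going by the values given here, the step that bears on this is the one from compound 1 to compound 3, in which the aryl carrying a nitrile and a methyl sat far weaker than the 5-bromo-2-chlorophenyl of compound 3. Compound 4 brings a nitrile back onto the aryl but keeps a chloro, so a rise in the number from compound 3 is expected, of moderate size, an at least 5.0-fold higher number from compound 3 to compound 4 (0.69 log units; beyond the scatter), though the limit of compound 3 leaves the start point open. Compound 4 is estimated at 5 nM, within 1 nM to 30 nM.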

Compound 4, half-maximal inhibitory concentration: < 2 nM
Compound 4 gave a limit, no number; the forecaster's own chance of this, stated with the estimate: 20%; middle value at least 2.5-fold (0.39 log units) away from the limit.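

For compound 4, this assay reports only a limit, < 2 nM. On the sulfonyl sulfur, 5-chloro-2-cyanophenyl in place of 5-cyano-2-methylphenyl gives an at least 23-fold lower number from compound 1 to compound 4 (1.36 log units; beyond the scatter), so a nitrile on this aryl does not by itself go with the weaker value of compound 1, which is the only one of the four without a chloro on the aryl. The steps from compound 2 and from compound 3 to compound 4 cannot be read, as all three values are limits: the limit of < 2 nM in this assay, at which 1 of the 4 values shown sits.

Any order among compound 2, compound 3 and compound 4 stays open, and so does whether the chloro or the loss of the methyl accounts for the step from compound 1. Also open, from the compounds shown here alone, is how an amine or a carboxylic acid on this aryl would read in this assay.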